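Three Flat Readings and a Smaller Aryl Group

A few compounds are considered here, and "the series" means these few. Any claim that something is new, unique, unknown or untested is made for them only; others in the source may bear on it.

Compound 3 `COc1cc(N2C(N)=C(C#N)C(c3c(O)ccc4ccccc34)C3=C2CC(C)(C)CC3=O)cc(OC)c1OC` is one of three compounds examined in a functional assay on Ehrlich cells (Mus musculus) for cytotoxicity, tested at 10 ug/mL; on this read-out higher numbers stand for a stronger effect at the one concentration tested and lower numbers for a weaker effect. In that assay compound 3 gives 2%. Compound 1 `COc1ccc(C2C(C#N)=C(N)N(c3cc(OC)c(OC)c(OC)c3)C3=C2C(=O)CC(C)(C)C3)cc1` gives 0% in this assay, and compound 2 `COc1cc(N2C(N)=C(C#N)C(c3c(OC)ccc4ccccc34)C3=C2CC(C)(C)CC3=O)cc(OC)c1OC` gives 0%. Compound 3 thus stands at the highest of the three numbers, but both gaps lie within the scatter: a number 2 percentage points higher from compound 1 to compound 3 (within the scatter) and a number 2 percentage points higher from compound 2 to compound 3 (within the scatter). Compound 4 `COc1ccccc1C1C(C#N)=C(N)N(c2cc(OC)c(OC)c(OC)c2)C2=C1C(=O)CC(C)(C)C2` has not yet been measured. (2-methoxyphenyl in place of 2-hydroxynaphthalen-1-yl on a saturated ring carbon). Among the measured compounds shown here, two measured steps bear on this change, since each swapped one aryl group for another on the same saturated ring carbon: no change at the digits printed from compound 1 to compound 2 (within the scatter) and a number 2 percentage points higher from compound 1 to compound 3 (within the scatter), neither of which moved the read-out beyond the scatter. Because no change at the digits printed from compound 1 to compound 2 (within the scatter) and a number 2 percentage points higher from compound 1 to compound 3 (within the scatter) were both flat, compound 4 is expected to show a number 1 percentage points lower from compound 3 to compound 4 (within the scatter), no step beyond the scatter in this assay. The estimate for compound 4 is 1%, with a range from 0% to 8%.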

Compound 4, a percentage reported as activity, at one concentration (the size of the read-out at that concentration, not a potency): 30%
Estimate against measurement, compound 4: 29 percentage points below; the measured number lies above the stated range.
By their numbers in this assay, from the lowest: compounds 1, 2 and 3 (each within the scatter of the next); then compound 4.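

In this assay, the aryl group on this saturated ring carbon now proves able to change the read-out: 2-methoxyphenyl gives a number 28 percentage points higher from compound 3 to compound 4 (beyond the scatter), a number 30 percentage points higher from compound 2 to compound 4 (beyond the scatter) and a number 30 percentage points higher from compound 1 to compound 4 (beyond the scatter). The last of these steps is the most telling, since 4-methoxyphenyl and 2-methoxyphenyl each carry one six-membered aromatic ring, so among these compounds a single ring in place of two is not enough on its own, and compound 1 goes against any such reading. No measurement available here accounts for the rise.

The compounds shown leave open whether the effect needs the methoxy group itself, which 2-hydroxyphenyl, 2-ethoxyphenyl or 2-chlorophenyl at this carbon would address. They also leave open how compound 4 behaves at any concentration other than the one tested.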